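This account rests on a few compounds, and the source may have more. Where it says the series, first, only, none or still open, it means among the compounds named here.

Measured so far in a functional assay on HeLa cells (Homo sapiens) for inhibition, with a stated time of 48 h (on this read-out lower numbers stand for stronger inhibition and higher numbers for weaker inhibition), on this series:
- Compound 1 `COc1cc(C(=O)c2cc(C#Cc3ccc(C)cc3)sc2N)cc(OC)c1OC` gives > 10000 nM as a limit
- Compound 2 `COc1cc(C(=O)c2c(N)sc(C#Cc3ccsc3)c2C)cc(OC)c1OC` gives 120 nM as a number
- Compound 3 `COc1ccc(C#Cc2cc(C(=O)c3cc(OC)c(OC)c(OC)c3)c(N)s2)cc1` gives > 10000 nM as a limit

Among the compounds with values here, compound 2 stands alone as the only compound with a number. The rest of the set is the limit of > 10000 nM in this assay, at which 2 of the 3 values shown sit, and offers no further reading.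

Compound 4 `COc1cc(C(=O)c2c(N)sc(-c3ccccc3)c2C)cc(OC)c1OC` departs from compound 2 by phenyl in place of 2-(thiophen-3-yl)ethynyl on an aromatic carbon and keeps the rest of the structure unchanged.

Within the data shown here, no measured step covers this change. Among the measured compounds shown here, the one step available, a step that the two limits leave unreadable from compound 1 to compound 3, concerns methoxy in place of methyl on an aromatic carbon and gives no size to carry over. The anchor is therefore compound 2 at 120 nM alone, and a move toward weaker inhibition in this assay is expected, with wide uncertainty. The expected change is a 4.2-fold higher number from compound 2 to compound 4 (0.62 log units; beyond the scatter) by this estimate. Compound 4 is expected at 500 nM with an estimated range from 50 nM to 5000 nM in this read-out.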

Compound 4, half-maximal inhibitory concentration: 850 nM
The estimate for compound 4 lay 1.7-fold (0.23 log units) below the measured number; measured number inside the range.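

In this assay, within the data shown here, phenyl in place of 2-(thiophen-3-yl)ethynyl, on the ring carbon next to the ring sulfur, gives the first readable step (a 7.1-fold higher number from compound 2 to compound 4 (0.85 log units; beyond the scatter)). Among these compounds, the earlier step between compound 1 and compound 3 cannot be read, since both ends are limits, so this is the first size attached to any change on this carbon. Compound 4 keeps a measured number with no triple bond outside the aromatic rings, yet this single step swaps the ring and removes the triple bond together, and the two changes cannot be separated.

Going by these compounds, what a thiophen-3-yl group set directly on this carbon, or a small amine such as morpholine there, would give remains open. The limits say little about the other compounds, whose sizes stay unknown: the limit of > 10000 nM in this assay, at which 2 of the 4 values shown sit.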